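The compounds below may be only part of what the source reports. "The series", "measured", "known", "first", "only" and "open" are said of these compounds alone.

Compound 1 `c1ccc(C(/N=C2\CCCCCN2)C2CC2)cc1`: 5%
Compound 2 `COc1ccc(C(/N=C2\CCCCCN2)C2CC2)cc1`: 1%

In a functional assay on the whole organism (plasma, strain Sprague-Dawley) with Rattus norvegicus as the target, with a stated time of 2 h, at a dose of 12.5 mg/kg by the oral route (a lower number here means a weaker effect, a higher number a stronger effect of the compound at the dose given), compound 1 gives 5%, the larger of the two numbers shown. Compound 2 gives 1% in this assay. Among the compounds with values here, the one recorded step, a number 4 percentage points lower from compound 1 to compound 2 (within the scatter), lies within the scatter. Compound 3 `c1ccc(C(/N=C2\CCCCCN2)C2CCC2)cc1` differs from compound 1 by cyclobutyl in place of cyclopropyl on a saturated chain carbon bound to an aromatic carbon and a double-bonded nitrogen. Within the data shown here, no measured step touches this group, and the single step known concerns another place and was within the scatter, so no step beyond the scatter is expected here. Compound 3 is expected to give 5%, with a range from -5% to 15%. The expected step is no change at the digits printed from compound 1 to compound 3 (within the scatter).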

Compound 3, a percentage reported as inhibition, in the whole organism at one dose (the size of the read-out at that dose, not a potency): 14%
Compound 3: middle estimate off by 9 percentage points, on the low side, and the stated range covers the measured number.
By their numbers in this assay, from the lowest: compounds 2, 1 and 3 (each within the scatter of the next, the first and the last beyond it).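

In this assay, cyclobutyl in place of cyclopropyl on a saturated chain carbon bound to an aromatic carbon and a double-bonded nitrogen gives a number 9 percentage points higher from compound 1 to compound 3 (within the scatter), the only step shown at this position. This pair therefore gives no firm sign that going from the three-membered to the four-membered ring matters here. No evidence is available that bears on this step. From the compounds shown here alone, it remains open how cyclopentyl, or an open chain such as isopropyl, would read at this place. Also open, going by these compounds, is whether methoxy on the aromatic ring would read the same alongside cyclobutyl.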